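Piperidine ring in place of the hydroxyl-ended chain

The source may report more compounds than this note shows. Statements on the series, on what has been measured and on what is new or still open speak of the compounds shown alone.

Compound 1 `COc1cc(N)c(Cl)cc1C(=O)NC1CCN(CCCCCO)CC1` has been measured in a functional assay on HEK293 cells for agonist activity at 5-hydroxytryptamine receptor 4 (Homo sapiens), read by cAMP accumulation (on this read-out higher numbers stand for an effect only at larger amounts of compound and lower numbers for an effect already at smaller amounts), and gives 15.9 nM. Among the two compounds measured so far it holds the highest number; its only neighbour is compound 2 `COc1cc(N)c(Cl)cc1C(=O)NC1CCN(CCCCCN2C(=O)c3ccccc3C2=O)CC1`, which gives 5.01 nM. For the measured compounds named here, the single measured step, a 3.2-fold lower number from compound 1 to compound 2 (0.50 log units; beyond the scatter), exchanges one oxygen atom for a larger group at the far end of the side chain, five bonds along the chain from an amine nitrogen in a ring. Compound 3 `COc1cc(N)c(Cl)cc1C(=O)NC1CCN(CCN2CCCCC2)CC1` differs from compound 1 at another place: piperidin-1-yl in place of 3-hydroxypropyl on a saturated chain carbon, two bonds along the chain from an amine nitrogen in a ring. Cut one bond further out, the same difference reads 5-hydroxypentyl to 2-(piperidin-1-yl)ethyl. Going by the values given here, no measured step touches this position; the step from compound 1 to compound 2 bears on it only in showing that the end of this chain accepts a large change without a loss. For compound 3 a step of about the scatter, in either direction, is therefore expected: a 1.3-fold lower number from compound 1 to compound 3 (0.12 log units; within the scatter). Compound 3 is accordingly estimated at 12 nM, within a range from 3 nM to 50 nM.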

Compound 3, half-maximal effective concentration: 100 nM
Beside the measured number, compound 3's estimate is 8.3-fold (0.92 log units) below it; the measured number lies above the stated range.
By their numbers in this assay, from the lowest: compound 2; then compound 1; then compound 3.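

In this assay, this position proves sensitive to the change: a 6.3-fold higher number from compound 1 to compound 3 (0.80 log units; beyond the scatter), with piperidin-1-yl in place of 3-hydroxypropyl, two bonds along the chain from an amine nitrogen in a ring. For the compounds shown here, the earlier step, a 3.2-fold lower number from compound 1 to compound 2 (0.50 log units; beyond the scatter), showed only that a large group could be accepted on the 5-hydroxypentyl chain, whereas this result shows that the replacement of 5-hydroxypentyl by 2-(piperidin-1-yl)ethyl is not tolerated equally well, and so the chain does not accept every change at this place without a loss. No measurement at hand offers an explanation for this step.

The compounds shown leave open whether the higher number follows the piperidine ring itself or the change from a pentyl to an ethyl chain, since both differ together in compound 3, and a 5-(piperidin-1-yl)pentyl chain would separate the two. On these data alone, it also remains open how a 2-hydroxyethyl chain, or a morpholine ring on the ethyl chain, would read out on the same measure.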